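Three analogues and a trifluoromethyl swap

The compounds below may be only part of what the source reports. "The series", "measured", "known", "first", "only" and "open" are said of these compounds alone.

Measured in an ADME assay on microsomes from liver (Mus musculus) for metabolic stability, read by LC-MS, using NADPH, with stated times of 6 min and 10 min, tested at 0.5 uM (on this read-out higher numbers stand for a more stable compound and lower numbers for a less stable compound), so far:
- compound 1 `CC(=O)N1CCN(c2cccc(-c3cc(Cl)c4c(N)ncnn34)c2C)C(=O)C1(C)C` gives 1% remaining
- compound 2 `CC(=O)N1CCN(c2cc(C)cc(-c3cc(Cl)c4c(N)ncnn34)c2)C(=O)C1(C)C` gives 45% remaining
- compound 3 `CC(=O)N1CCN(c2cc(-c3cc(Cl)c4c(N)ncnn34)ccc2C(F)(F)F)C(=O)C1(C)C` gives 88% remaining

Compound 3 at 88% stands highest of the three, beyond the scatter above both compound 2 and compound 1. Among the compounds with values here, no two measured compounds differ in one place only, so no measured step can serve as a direct guide.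

The next compound is compound 4 `COc1ccc(-c2cc(Cl)c3c(N)ncnn23)cc1N1CCN(C(C)=O)C(C)(C)C1=O` with methoxy in place of trifluoromethyl on an aromatic carbon, ortho to a large group and para to a large group methoxy in place of trifluoromethyl on an aromatic carbon relative to compound 3.

Compound 1 at 1% shows how low a close analogue can fall, and compound 3 at 88% leaves little room upward. A downward move beyond the scatter is therefore expected. The estimated change is a number 33 percentage points lower from compound 3 to compound 4 (beyond the scatter) in this assay with wide uncertainty. For compound 4 the expected value is 55% within an estimated range of 25% to 80% in this assay when measured.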

Compound 4, percent of the compound remaining: 94%
Compound 4: the middle estimate sits 39 percentage points below what was measured, and the stated range ends below it.
By their numbers in this assay, from the lowest: compound 1; then compound 2; then compounds 3 and 4 (each within the scatter of the next).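

In this assay, within the data shown here, the step of a number 6 percentage points higher from compound 3 to compound 4 (within the scatter) is the first measured change in one place. It shows that, on this aromatic carbon, ortho to a large group and para to a large group, methoxy can take the place of trifluoromethyl with no change in this read-out beyond the scatter. The two groups differ in heavy atoms and in hydrogen-bond acceptors, yet this pair gives no measurable separation between them, and nothing available bears on the reason.

As far as these compounds go, whether a hydrogen, a nitrile, an amine or a carboxylic acid on this carbon would also hold the read-out remains open. Also open, from the compounds shown here alone, is whether the same swap would give the same result elsewhere on this ring.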